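Series notes: chain-end change from compound 3 to compound 4

This account rests on a few compounds, and the source may have more. Where it says the series, first, only, none or still open, it means among the compounds named here.

Three compounds of the shared core have numbers in an assay on isolated protein for inhibition of leukotriene B4 receptor 1 (Homo sapiens), tested at 10 uM; on this read-out lower numbers stand for less inhibition and higher numbers for more inhibition at the one concentration tested (going by the name of the read-out). Compound 1 `CC(=O)c1cc(C)c(OCCCCC#N)cc1O` gives 79% in this assay. Compound 2 `CCCCCc1cc(C(C)=O)c(O)cc1OCCCCC#N` gives 31% in this assay, and compound 3 `C=CCc1cc(C(C)=O)c(O)cc1OCCCCC#N` gives 92%. Compound 3 stands highest of the three: its nearest neighbour is compound 1, as a number 13 percentage points higher from compound 1 to compound 3 (beyond the scatter) shows, and the furthest is compound 2, as a number 61 percentage points higher from compound 2 to compound 3 (beyond the scatter) shows. The remaining step, a number 48 percentage points lower from compound 1 to compound 2 (beyond the scatter), sits at the same place, the saturated chain carbon bound to an aromatic carbon.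

Compound 4 `C=CCc1cc(C(C)=O)c(O)cc1OCCCCCC(=O)OC` is not yet measured. It differs from compound 3 as follows: (methoxycarbonyl)methyl in place of cyano on a saturated chain carbon, four bonds along the chain from an oxygen on an aromatic ring. Within the data shown here, every measured step in this assay concerns the saturated chain carbon bound to an aromatic carbon; none touches the far end of the chain that carries the cyano group, so no measured step bears on this change. With nothing to go on, the number of compound 3 is taken as the starting point. The step that the estimate implies is expected to be a number 7 percentage points lower from compound 3 to compound 4 (within the scatter), which lies within the scatter. Compound 4 is therefore estimated at 85% in this assay, with a range from 60% to 99%.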

Compound 4, a percentage reported as inhibition, at one concentration (the size of the read-out at that concentration, not a potency): 106%
Compound 4: the middle estimate sits 21 percentage points below what was measured, and the stated range ends below it.
By their numbers in this assay, from the lowest: compound 2; then compound 1; then compound 3; then compound 4.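

Among these compounds, the far end of the chain, which no earlier step touched, proves to matter in this assay: a number 14 percentage points higher from compound 3 to compound 4 (beyond the scatter), so this position is not indifferent to the change from cyano to (methoxycarbonyl)methyl. The position also accepts the larger group, with 5 heavy atoms and 2 hydrogen-bond acceptors entering where 2 heavy atoms and 1 hydrogen-bond acceptor leave, and the reading does not fall on the core of compound 3. No measured information on these compounds speaks to what lies behind this step.

On these data alone, this rests on one pair at one concentration, so compound 4 at 106% gives no potency, and whether the same change carries over to the cores of compound 1 and compound 2 remains open. Also open, as far as these compounds go, is how this chain end would respond to a carboxylic acid, a primary amide or an amine in place of the methyl ester, or to a longer or shorter chain carrying the same ester.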